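The source may hold more compounds than are shown below. What is called first, only, known or untested is meant among the compounds shown, and "the series" means these compounds.

Of the compounds shown here, three have been measured. Compound 1 `Nc1ccccc1NC(=O)CCCNCC(=O)Nc1ccc(Cl)cc1`, compound 2 `COc1ccc(NC(=O)CNc2ccc(C(=O)Nc3ccccc3N)cc2)cc1` and compound 3 `COc1ccc(NC(=O)CNCCCC(=O)Nc2ccccc2N)cc1` were each tested in a functional assay on HCT-116 cells (Homo sapiens) for inhibition, read by MTT assay, with a stated time of 2 days; a higher number here means a weaker inhibitor of growth, a lower number a stronger inhibitor of growth. In this assay compound 1 gives 5500 nM. In the same assay compound 2 gives 7500 nM. Compound 3 gives 8600 nM in the same assay.

Compound 3 and compound 1 differ in one place: chloro in place of methoxy on an aromatic carbon. That change gives a 1.6-fold lower number from compound 3 to compound 1 (0.19 log units; within the scatter), a step inside the scatter. Compound 2 and compound 3 differ in more than one place; the difference between the two cores is not broken down here, and their two numbers sit within the scatter of each other.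

Compound 4 `Nc1ccccc1NC(=O)c1ccc(NCC(=O)Nc2ccc(Cl)cc2)cc1` has not yet been measured. It differs from compound 2 in one place: chloro in place of methoxy on an aromatic carbon. The place is described in the same words as for the change from compound 3 to compound 1, on an aromatic carbon of a six-membered aromatic ring of carbon only, para to a large group, so this is the same change made a second time. Read one bond further out it also covers (4-methoxyphenyl)amino to (4-chlorophenyl)amino, which the earlier instance did not.

Going by the values given here, only one prior instance of this change exists. Among the compounds with values here, for compound 4 the expected step is a 1.5-fold lower number from compound 2 to compound 4 (0.18 log units; within the scatter), because a 1.6-fold lower number from compound 3 to compound 1 (0.19 log units; within the scatter) lay within the scatter and a step of about that size is the only guide available. The estimate for compound 4 in this assay is 5000 nM, with a range from 2500 nM to 10000 nM.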

Compound 4, concentration for 50% growth inhibition: 4200 nM
Beside the measured number, compound 4's estimate is 1.2-fold (0.08 log units) above it; the measured number falls inside the stated range.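

In this assay, chloro in place of methoxy on an aromatic carbon gives a 1.8-fold lower number from compound 2 to compound 4 (0.25 log units; within the scatter), and this step can be set directly against the one seen on the other core: the same change on two cores in this assay, a 1.6-fold lower number (0.19 log units; within the scatter) from compound 3 to compound 1 and a 1.8-fold lower number (0.25 log units; within the scatter) from compound 2 to compound 4, 1.1-fold (0.06 log units) apart, within the scatter of two such steps. In this small set, the change therefore carries from one core to the other with no difference that can be told apart, and the two cores give the same reading of it. It does not show that chloro gives a real gain over methoxy on either core, since each step taken alone lies within the scatter, and two instances with a single pair of groups set no rule for the rest of the series.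

The aromatic carbon para to a large group carries only methoxy or chloro in the compounds shown, so it remains open whether hydrogen, trifluoromethyl, an amine or a carboxylic acid at that place would give a step beyond the scatter on either core. Going by these compounds alone, also open is whether the same change would still carry across with a longer chain in place of the one in compound 1 and compound 3.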